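The source may report more compounds than this note shows. Statements on the series, on what has been measured and on what is new or still open speak of the compounds shown alone.

Measured compounds:
compound 1, `Cc1oc(-c2ccc(Cl)cc2)nc1CN1CCC(C(=O)NCCCN2C[C@H](C)C[C@H](C)C2)CC1` — in an ADME assay on microsomes from liver (Rattus norvegicus) for metabolic stability, read by LC-MS, using NADPH, at 37 degrees C (on this read-out lower numbers stand for a shorter-lived compound and higher numbers for a longer-lived compound), compound 1 gives > 0.5 h, a limit of the assay rather than a number.
compound 2, `Cc1oc(-c2c(F)cccc2F)nc1CN1CCC(C(=O)NCCCN2C[C@H](C)C[C@H](C)C2)CC1` — in this assay compound 2 gives 0.35 h.

Compound 2 therefore holds the only number shown; the other value is a limit, (the limit of > 0.5 h in this assay, at which 1 of the 2 values shown sits). Within the data shown here, the single measured step is an at least 1.4-fold lower number from compound 1 to compound 2 (0.15 log units; that floor lies within the scatter), and its floor lies within the usual scatter, so it settles little about direction or size.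

Compound 3, `Cc1cccc(F)c1-c1nc(CN2CCC(C(=O)NCCCN3C[C@H](C)C[C@H](C)C3)CC2)c(C)o1`, differs from compound 2 by methyl in place of fluoro on an aromatic carbon. Among the measured compounds shown here, no measured step touches this change: the only step that has been measured exchanges one substituted phenyl for another, not a single substituent on the same ring. The expectation for compound 3 is consequently a step of no change at the digits printed from compound 2 to compound 3 (within the scatter), that is, nothing beyond the scatter. Compound 3 is estimated at 0.35 h, with a range from 0.15 h to 0.8 h.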

Compound 3, half-life: 0.0733 h
The estimate for compound 3 lay 4.8-fold (0.68 log units) above the measured number; the measured number lies below the stated range.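

Swapping 2,6-difluorophenyl for 2-fluoro-6-methylphenyl shows that exchanging one heavy atom at this position, ortho to a large group, can move the half-life in this assay beyond the scatter, which the earlier step could not establish: a 4.8-fold lower number from compound 2 to compound 3 (0.68 log units; beyond the scatter). Set against the 4-chlorophenyl of compound 1, the result is an at least 6.8-fold lower number from compound 1 to compound 3 (0.83 log units; beyond the scatter). That step gives only a floor, since the value of compound 1 is a limit of the assay: the limit of > 0.5 h in this assay, at which 1 of the 3 values shown sits.

Whether the shorter half-life is specific to methyl stays open, as no other group, such as chloro, methoxy or a nitrile, is shown at this position. The compounds shown also leave open what a 2,6-dimethylphenyl, with methyl in place of the remaining fluoro, would give.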